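Swapping the Thioether Arm: Methoxybenzyl to Phenethyl

The source may hold more compounds than are shown below. What is called first, only, known or untested is meant among the compounds shown, and "the series" means these compounds.

Compound 1, `CC(C)CCSc1nc(C(F)(F)F)ccc1CNC(=O)C(C)c1ccc(NS(C)(=O)=O)c(F)c1`: 82 nM
Compound 2, `CC(C(=O)NCc1ccc(C(F)(F)F)nc1SCc1ccc(Cl)cc1)c1ccc(NS(C)(=O)=O)c(F)c1`: 674 nM
Compound 3, `COc1ccc(CSc2nc(C(F)(F)F)ccc2CNC(=O)C(C)c2ccc(NS(C)(=O)=O)c(F)c2)cc1`: 279 nM

Of the compounds shown here, three sharing one core have been measured in an assay on CHO-K1 cells for antagonist activity at transient receptor potential cation channel subfamily V member 1 (Homo sapiens), read by FLIPR; a lower number here means a stronger inhibitor, a higher number a weaker inhibitor. Compound 3 holds the second highest number of the three: a 2.4-fold lower number from compound 2 to compound 3 (0.38 log units; beyond the scatter) separates it from compound 2, and a 3.4-fold higher number from compound 1 to compound 3 (0.53 log units; beyond the scatter) from compound 1. Compound 4, `CC(C(=O)NCc1ccc(C(F)(F)F)nc1SCCc1ccccc1)c1ccc(NS(C)(=O)=O)c(F)c1`, carries the change (benzyl in place of 4-methoxyphenyl on a saturated chain carbon bound to a sulfur). Within the data shown here, the steps that bear on this are those at the same place, an 8.2-fold higher number from compound 1 to compound 2 (0.91 log units; beyond the scatter) and a 3.4-fold higher number from compound 1 to compound 3 (0.53 log units; beyond the scatter), both modest, and in both an aryl group on that carbon gave a higher number than the branched chain. A benzyl group there sits between those cases, so for compound 4 a small step toward a lower number is expected, a 1.4-fold lower number from compound 3 to compound 4 (0.14 log units; within the scatter). For compound 4 the estimated value in this assay is 200 nM, within 70 nM to 600 nM.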

Compound 4, half-maximal inhibitory concentration: 111 nM
For compound 4 the middle estimate is 1.8-fold (0.26 log units) above the measured one, and the stated range covers the measured number.
By their numbers in this assay, from the lowest: compounds 1 and 4 (each within the scatter of the next); then compound 3; then compound 2.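

In this assay, going from the 4-methoxybenzyl to the phenethyl arm gives a 2.5-fold lower number from compound 3 to compound 4 (0.40 log units; beyond the scatter), and leaving the chlorinated benzyl arm for phenethyl gives a 6.1-fold lower number from compound 2 to compound 4 (0.78 log units; beyond the scatter). Among these compounds, an aromatic ring on this thioether arm therefore need not carry the penalty seen in the earlier compounds: phenyl in place of isopropyl gives a 1.4-fold higher number from compound 1 to compound 4 (0.13 log units; within the scatter), and that step lies within the scatter. Nothing available explains these steps. Still open, from the compounds shown here alone, is whether a methoxy or chloro group on the phenethyl ring would be tolerated, and whether a longer chain such as 3-phenylpropyl would hold this level.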